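The source may hold more compounds than are shown below. What is called first, only, known or untested is meant among the compounds shown, and "the series" means these compounds.

In an assay on HEK293 cells for agonist activity at transient receptor potential cation channel subfamily M member 8 (Homo sapiens), read by fluorescence and calcium flux, with a stated time of 15 min (on this read-out higher numbers stand for an effect only at larger amounts of compound and lower numbers for an effect already at smaller amounts), compound 1 `Cc1ccc(OCC(=O)N(Cc2cccs2)c2ccn(C)n2)cc1` gives 855 nM, the highest of the two numbers seen so far; compound 2 `CCN(Cc1cccs1)C(=O)COc1ccc2c(c1)COC2` gives 61 nM in this assay, a markedly lower number. Compound 3 `CCCN(Cc1cccs1)C(=O)COc1ccc(C)cc1` has not yet been measured. It differs from compound 1 in one place: propyl in place of 1-methyl-1H-pyrazol-3-yl on an amide-type nitrogen. Compound 2, which also carries a short chain on its amide-type nitrogen, gives a low number, so the step from compound 1 to compound 3 in this assay is expected to move the number downward, beyond the scatter, by roughly a 3.9-fold lower number from compound 1 to compound 3 (0.59 log units; beyond the scatter). Compound 3 is therefore estimated at 220 nM, within a range of 60 nM to 800 nM.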

Compound 3, half-maximal effective concentration: 40 nM
For compound 3 the middle estimate is 5.5-fold (0.74 log units) above the measured one; measured number outside the range, below it.
By their numbers in this assay, from the lowest: compounds 3 and 2 (each within the scatter of the next); then compound 1.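

Replacing 1-methyl-1H-pyrazol-3-yl with propyl on the amide-type nitrogen gives a 21-fold lower number from compound 1 to compound 3 (1.33 log units; beyond the scatter) in this assay and shows that this one position can strongly change the number. An aromatic ring at this place is therefore not needed for a low number on the core of compound 3. Nothing available explains why the step is so large.

Still open, going by these compounds, is how methyl, butyl or a chain ending in an amine would behave on this nitrogen. On these data alone, it is also open whether phenyl would give a number like that of 1-methyl-1H-pyrazol-3-yl or like that of propyl.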